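The compounds below may be only part of what the source reports. "The series", "measured", "known", "first", "only" and "open" are said of these compounds alone.

Compound 1 `Clc1ccc(Cn2c(Br)nc3cc(Cl)c(Cl)cc32)cc1` was tested in a functional assay on KB cells (Homo sapiens) for inhibition (on this read-out higher numbers stand for weaker inhibition and lower numbers for stronger inhibition), where compound 1 gives > 100000 nM, a limit and not a number. Compound 2 `Clc1ccc(Cn2c(Br)nc3cc(Cl)c(Cl)cc32)cc1Cl` gives > 100000 nM, also a limit. Among the compounds with values here, neither compound therefore has a numerical position on this read-out, and the only evidence is the limit of > 100000 nM in this assay, at which 2 of the 2 values shown sit. Compound 3 `O=[N+]([O-])c1ccc(Cn2c(Br)nc3cc(Cl)c(Cl)cc32)cc1` alters the core of compound 1 at one place: nitro in place of chloro on an aromatic carbon. The nitro sits on an aromatic carbon, para to a large group. Within the data shown here, the only measured step that bears on this change is a step that the two limits leave unreadable from compound 1 to compound 2, which puts chloro in place of hydrogen on an aromatic carbon and offers no size to carry over. No change beyond the scatter is therefore expected in this assay, and a further limit is the likeliest report. The expected step is a number no higher from compound 1 to compound 3 (the limit leaves the size open). The expected value for compound 3 is 100000 nM, with an estimated range from 30000 nM to 300000 nM.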

Compound 3, half-maximal inhibitory concentration: 40000 nM
Compound 3: middle estimate off by 2.5-fold (0.40 log units), on the high side, and the stated range covers the measured number.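

In this assay, within the data shown here, the change at this place on the aromatic ring, para to a large group, gives the first step that can be read: an at least 2.5-fold lower number from compound 1 to compound 3 (0.39 log units; beyond the scatter). Among these compounds, the earlier step, like any other that rests on two limits, cannot be read, so this one is the first sign that the group at this place can move the read-out at all. Compound 3 is the only compound shown with a number, and the others stay at a limit: the limit of > 100000 nM in this assay, at which 2 of the 3 values shown sit.

On these data alone, compound 1 itself carries a limit and not a number, so how large the step really is remains open. Also open, as far as these compounds go, is whether the nitro is specific in this, or whether an amine, a nitrile or a carboxylic acid at the same place would give a similar number or a different one.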